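Compound 4 in the series: replacing the nitrophenyl arm

The source may report more compounds than this note shows. Statements on the series, on what has been measured and on what is new or still open speak of the compounds shown alone.

Among the compounds with values here, compound 3 `COc1cc(-n2cnc3ccc(-c4cccc([N+](=O)[O-])c4)cc32)cc(OC)c1OC` gives 4560 nM in a functional assay on MCF7 cells (Homo sapiens) for antiproliferative activity, read by MTT assay, with a stated time of 72 h (on this read-out higher numbers stand for weaker inhibition and lower numbers for stronger inhibition), and stands highest of the three numbers measured so far. Compound 1 `COc1cccc(-c2ccc3ncn(-c4cc(OC)c(OC)c(OC)c4)c3c2)c1` gives 1610 nM and compound 2 `COc1cc(-n2cnc3ccc(-c4cccc(C)c4C)cc32)cc(OC)c1OC` gives 2150 nM; the steps from these to compound 3 are a 2.8-fold higher number from compound 1 to compound 3 (0.45 log units; beyond the scatter) and a 2.1-fold higher number from compound 2 to compound 3 (0.33 log units; beyond the scatter), while the step between compound 1 and compound 2 is a 1.3-fold higher number from compound 1 to compound 2 (0.13 log units; within the scatter).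

The next compound, compound 4 `COc1cc(-n2cnc3ccc(-c4ccc(Cl)cc4Cl)cc32)cc(OC)c1OC`, differs from compound 3 only at the aryl arm: 2,4-dichlorophenyl in place of 3-nitrophenyl on an aromatic carbon. Within the data shown here, two measured steps bear on this. The step with nitro in place of methoxy was modest and beyond the scatter, as was the step from 2,3-dimethylphenyl to 3-nitrophenyl. Both point the same way: the 3-nitrophenyl compound sits at the weaker end, and the two arms without the nitro group sit within the scatter of each other. A 2,4-dichlorophenyl arm, which like 2,3-dimethylphenyl carries no hydrogen-bond acceptors, is therefore expected to move back toward compounds 1 and 2, a modest step downward in this assay, a 1.8-fold lower number from compound 3 to compound 4 (0.26 log units; within the scatter). For compound 4 the expected value in this assay is 2500 nM, with a range from 1000 nM to 6500 nM.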

Compound 4, half-maximal inhibitory concentration: 5420 nM
Compound 4: middle estimate off by 2.2-fold (0.34 log units), on the low side; measured number inside the range.
By their numbers in this assay, from the lowest: compounds 1 and 2 (each within the scatter of the next); then compounds 3 and 4 (each within the scatter of the next).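

Notes on the aryl arm, in this assay: exchanging 3-nitrophenyl for 2,4-dichlorophenyl leaves the number unresolved from that of compound 3 (a 1.2-fold higher number from compound 3 to compound 4 (0.08 log units; within the scatter)), so at this position the two arms cannot be told apart. The dichlorophenyl arm stays separate from the other two arms (a 2.5-fold higher number from compound 2 to compound 4 (0.40 log units; beyond the scatter); a 3.4-fold higher number from compound 1 to compound 4 (0.53 log units; beyond the scatter)), which shows that removing the nitro group does not by itself bring the series back to compounds 1 and 2, even though the entering arm has 0 hydrogen-bond acceptors against 2 in the arm it replaces. The series therefore falls into two pairs, compounds 1 and 2 on one side and compounds 3 and 4 on the other, and no measurement available here accounts for that split.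

The four arms differ both in the kind of substituent and in where it sits on the ring, so these compounds do not show which of the two governs the split. Also open, as far as these compounds go, is how the number responds to a phenyl arm carrying a single chlorine, an amine or a carboxylic acid.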